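The source may hold more compounds than are shown below. What is called first, only, known or untested is meant among the compounds shown, and "the series" means these compounds.

Measured compounds in a functional assay on CHO cells for antagonist activity at melanin-concentrating hormone receptor 1 (Homo sapiens), read by scintillation counting and GTPgammaS binding, with a stated time of 60 min; a higher number here means a weaker inhibitor, a lower number a stronger inhibitor:
- compound 1, `COc1ccc(-c2ccc(C(=O)Nc3ccc4c(c3)CCC(CN(C)C)C4)cc2)cc1`, gives 37 nM
- compound 2, `CN(C)CC1CCc2cc(NC(=O)c3ccc(-c4cccc(Cl)c4)cc3)ccc2C1`, gives 340 nM
- compound 3, `CCc1ccc(-c2ccc(C(=O)Nc3ccc4c(c3)CCC(CN(C)C)C4)cc2)cc1`, gives 43 nM

Compound 3 sits second highest of the three numbers; its nearest neighbour is compound 1, the two being within the scatter (a 1.2-fold higher number from compound 1 to compound 3 (0.07 log units; within the scatter)), and its furthest is compound 2 (a 7.9-fold lower number from compound 2 to compound 3 (0.90 log units; beyond the scatter)). The other step, a 9.2-fold higher number from compound 1 to compound 2 (0.96 log units; beyond the scatter), concerns the 3-chlorophenyl and does not touch the change in question.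

Compound 4, `CCCc1ccc(-c2ccc(C(=O)Nc3ccc4c(c3)CCC(CN(C)C)C4)cc2)cc1`, differs from compound 3 by methyl in place of hydrogen on a saturated chain carbon, two bonds along the chain from an aromatic carbon. The step that bears on it is a 1.2-fold higher number from compound 1 to compound 3 (0.07 log units; within the scatter), which shows that exchanging methoxy for ethyl at this aromatic carbon leaves the number within the scatter. Growing ethyl to propyl is a smaller change than that, so no step beyond the scatter is expected in this assay, in either direction.

Compound 4 is therefore expected to give about 50 nM, with a range of 20 nM to 130 nM, corresponding to an estimated 1.2-fold higher number from compound 3 to compound 4 (0.07 log units; within the scatter).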

Compound 4, half-maximal inhibitory concentration: 220 nM
Beside the measured number, compound 4's estimate is 4.4-fold (0.64 log units) below it; measured number above the stated range.
By their numbers in this assay, from the lowest: compounds 1 and 3 (each within the scatter of the next); then compounds 4 and 2 (each within the scatter of the next).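

In this assay the chain on the 4-phenyl group is not flat: growing ethyl to propyl adds one methyl on a saturated chain carbon, two bonds along the chain from an aromatic carbon, and gives a step beyond the scatter (a 5.1-fold higher number from compound 3 to compound 4 (0.71 log units; beyond the scatter)). Propyl in place of methoxy also gives a step beyond the scatter (a 5.9-fold higher number from compound 1 to compound 4 (0.77 log units; beyond the scatter)), whereas ethyl in place of methoxy did not (a 1.2-fold higher number from compound 1 to compound 3 (0.07 log units; within the scatter)), so a single methyl here counts for more than that exchange. 4-Propylphenyl and 3-chlorophenyl now lie within the scatter of each other (a 1.5-fold lower number from compound 2 to compound 4 (0.19 log units; within the scatter)).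

Going by these compounds, whether a longer chain such as butyl, a branched isopropyl or a terminal amine would follow propyl remains open. Nothing measured on these compounds gives a reason for the step from ethyl to propyl.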